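Benzyloxy for Methoxy on the Tetrazole-Bearing Scaffold

The source may hold more compounds than are shown below. What is called first, only, known or untested is meant among the compounds shown, and "the series" means these compounds.

Among the measured compounds shown here, compound 2 `CCc1cc(C(C)=O)c(OC)cc1OCCCCCC(C)(C)c1nnn[nH]1` is one of two compounds measured in an assay on isolated protein for antagonist activity at Bile acid receptor (Homo sapiens), read by HTRF, with a stated time of 30 min; a lower number here means a stronger inhibitor, a higher number a weaker inhibitor. In this assay compound 2 gives 5500 nM, and compound 1 `CCCCc1cc(C(C)=O)c(OCc2ccccc2)cc1OCCCCCC(C)(C)c1nnn[nH]1` gives 7800 nM; the two numbers lie within the usual scatter of each other. Compound 3 `CCc1cc(C(C)=O)c(OCc2ccccc2)cc1OCCCCCC(C)(C)c1nnn[nH]1` carries phenyl in place of hydrogen on a saturated chain carbon bound to an oxygen on an aromatic ring. For the measured compounds named here, no measured pair shows this change by itself, so the step from compound 2 to compound 3 is expected to be small, in either direction, or none beyond the scatter, in part because compound 1 with the same benzyloxy group gives 7800 nM. Compound 3 is therefore estimated at 6500 nM, within a range of 2500 nM to 17000 nM, a step of a 1.2-fold higher number from compound 2 to compound 3 (0.07 log units; within the scatter).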

Compound 3, half-maximal inhibitory concentration: 1100 nM
Beside the measured number, compound 3's estimate is 5.9-fold (0.77 log units) above it; measured number outside the range, below it.
By their numbers in this assay, from the lowest: compound 3; then compounds 2 and 1 (each within the scatter of the next).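

In this assay the change from methoxy to benzyloxy gives a 5.0-fold lower number from compound 2 to compound 3 (0.70 log units; beyond the scatter) and so shows that this position, a saturated chain carbon bound to an oxygen on an aromatic ring, responds to added phenyl. With benzyloxy kept, hydrogen in place of ethyl on a saturated chain carbon, two bonds along the chain from an aromatic carbon, gives a 7.1-fold lower number from compound 1 to compound 3 (0.85 log units; beyond the scatter) and so shows that the gain from benzyloxy appears only with the shorter chain in compound 3. Nothing available explains either step.

Still open, from the compounds shown here alone, is whether a longer chain between the oxygen and the phenyl would lower the number further. Also open, going by these compounds, is how an amine or a carboxylic acid on that phenyl would act.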